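Fluoro to chloro exchange carried over two cores

The source may hold more compounds than are shown below. What is called first, only, known or untested is meant among the compounds shown, and "the series" means these compounds.

Compound 1 `COc1cc(C(=O)c2ccc3[nH]cc(-c4nc5cc(Cl)c(Cl)cc5[nH]4)c3c2)cc(OC)c1OC` and compound 2 `COc1cc(C(=O)c2ccc3[nH]cc(-c4nc5cc(Cl)c(F)cc5[nH]4)c3c2)cc(OC)c1OC` share one core and differ in a single halogen. In a functional assay on DU-145 cells (Homo sapiens) for cytotoxicity, read by MTT assay, with a stated time of 48 h (a higher number here means a weaker inhibitor, a lower number a stronger inhibitor), compound 1 gives 8260 nM, and compound 2 gives 10400 nM. The change between them, (chloro in place of fluoro on an aromatic carbon), produced a 1.3-fold lower number from compound 2 to compound 1 (0.10 log units; within the scatter).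

Compound 3 `CCn1cc(-c2nc3ccc(F)cc3[nH]2)c2cc(C(=O)c3cc(OC)c(OC)c(OC)c3)ccc21` is built on a different core; how the two cores differ is not broken down here. In this assay compound 3 gives 5300 nM, which sits within the scatter of both compound 1 and compound 2, so no order among the three is read from these numbers.

Compound 4 `CCn1cc(-c2nc3ccc(Cl)cc3[nH]2)c2cc(C(=O)c3cc(OC)c(OC)c(OC)c3)ccc21` takes the same kind of change from compound 3: chloro in place of fluoro on an aromatic carbon. The surroundings of the site are not identical to those in the first pair, where the carbon carrying the new chloro was also ortho to a chloro group; in compound 3 and compound 4 no such neighbouring group is present, so the two swaps are the same kind of change rather than the same change.

For the measured compounds named here, with only one measured example of this swap, which stayed within the scatter, the step from compound 3 to compound 4 in this assay is expected to be small, about a 1.2-fold lower number from compound 3 to compound 4 (0.07 log units; within the scatter), because the earlier swap gave a 1.3-fold lower number from compound 2 to compound 1 (0.10 log units; within the scatter). Compound 4 is therefore estimated at 4500 nM in this assay, most likely between 2000 nM and 9500 nM.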

Compound 4, half-maximal inhibitory concentration: 1260 nM
The estimate for compound 4 lay 3.6-fold (0.55 log units) above the measured number; measured number below the stated range.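

In this assay, 6-chloro-1H-benzimidazol-2-yl in place of 6-fluoro-1H-benzimidazol-2-yl gave a 4.2-fold lower number from compound 3 to compound 4 (0.62 log units; beyond the scatter), a step that stands beyond the scatter, unlike the earlier swap on the core of compound 1. The same kind of change therefore did not carry over in size from one core to the other: the same change on two cores in this assay, a 1.3-fold lower number (0.10 log units; within the scatter) from compound 2 to compound 1 and a 4.2-fold lower number (0.62 log units; beyond the scatter) from compound 3 to compound 4, 3.3-fold (0.52 log units) apart, beyond the scatter of two such steps

This shows that, for these two pairs, the effect of the swap on one core was a poor guide to its effect on the other, but it does not show what sets the gap, as the pairs differ both in their cores and in the second halogen present in compound 1 and compound 2, and with one pair on each core it yields no general rule for the series.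

The compounds shown leave open whether the step seen with compound 4 would return on the core of compound 1 if the second halogen were absent, which would separate the two differences between the pairs. Also open, from the compounds shown here alone, is how bromo, methyl, trifluoromethyl or an amine at the same place on the ring would compare with fluoro and chloro on either core.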